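The source may hold more compounds than are shown below. What is called first, only, known or untested is meant among the compounds shown, and "the series" means these compounds.

In an ADME assay on L6 cells (Rattus norvegicus) for inhibition, read by resazurin assay, with a stated time of 72 h (on this read-out lower numbers stand for stronger inhibition and higher numbers for weaker inhibition), compound 1 (`CSC[C@H]1O[C@@H](n2cnc3c(N)nc(Cl)nc32)[C@H](OC(C)=O)[C@@H]1OC(C)=O`) gives 216000 nM and lies within the scatter of compound 3 (`CC(=O)NC[C@H]1O[C@@H](n2cnc3c(N)nc(F)nc32)[C@H](OC(C)=O)[C@@H]1OC(C)=O`) at 138000 nM while compound 2 (`C[S+]([O-])C[C@H]1O[C@@H](n2cnc3c(N)nc(F)nc32)[C@H](O)[C@@H]1O`) reads 13000 nM and stands beyond the scatter on the lower side of compound 1. In compound 4 (`CC(=O)O[C@@H]1[C@H](OC(C)=O)[C@@H](CN2C(=O)c3ccccc3C2=O)O[C@H]1n1cnc2c(N)nc(Cl)nc21`) the methylsulfanyl on a saturated chain carbon bound to a saturated ring carbon gives way to a group of 11 heavy atoms (a group of 11 heavy atoms (8 carbon, 1 nitrogen, 2 oxygen; one five-membered non-aromatic ring with 1 hetero atom, one six-membered aromatic ring of carbon only) in place of a group of 2 heavy atoms (1 carbon, 1 sulfur; no ring), on a saturated chain carbon bound to a saturated ring carbon). Among the measured compounds shown here, no measured step covers this change. Only a small shift toward a lower number in this assay is expected, none beyond the scatter, since compound 3 with a nitrogen on that chain carbon gives 138000 nM within the scatter of compound 1. The expected step is a 1.7-fold lower number from compound 1 to compound 4 (0.22 log units; within the scatter) by this estimate. Compound 4 is estimated at 130000 nM (range 40000 nM to 320000 nM).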

Compound 4, half-maximal inhibitory concentration: 144000 nM
Compound 4: the middle estimate sits 1.1-fold (0.04 log units) below what was measured; the range from low to high includes it.
By their numbers in this assay, from the lowest: compound 2; then compounds 3, 4 and 1 (each within the scatter of the next).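

In this assay, replacing methylsulfanyl with the group of 11 heavy atoms, which carries a five-membered non-aromatic ring and a six-membered aromatic ring, gives a 1.5-fold lower number from compound 1 to compound 4 (0.18 log units; within the scatter). On a saturated chain carbon bound to a saturated ring carbon, this much larger two-ring group therefore leaves the number within the scatter. No measurement shown accounts for this result. As far as these compounds go, what an amine or a carboxylic acid on that chain carbon would read remains open. Also open, from the compounds shown here alone, is whether the same exchange would behave alike on a core with free hydroxyl groups instead of acetates.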